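Vero cytotoxicity notes for a chalcone-amide series

The source may report more compounds than this note shows. Statements on the series, on what has been measured and on what is new or still open speak of the compounds shown alone.

Measured so far in an ADME assay on Vero cells (Chlorocebus sabaeus) for cytotoxicity, read by MTT assay, with a stated time of 72 h; a higher number here means that more compound is tolerated, a lower number that less compound is tolerated:
compound 1 `COC(=O)c1cc(-c2cccc(NC(=O)c3ccc(/C=C/C(=O)c4cc(OC)c(OC)c(OC)c4)cc3)c2)on1` gives > 50 ug/mL
compound 2 `COC(=O)c1cc(-c2cccc(NC(=O)c3ccc(/C=C/C(=O)c4ccccc4Br)cc3)c2)on1` gives > 40 ug/mL
compound 3 `COC(=O)c1cc(-c2cccc(NC(=O)c3ccc(/C=C/C(=O)c4ccc(Cl)cc4Cl)cc3)c2)on1` gives > 40 ug/mL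

Every value here is a limit of the assay, not a number. For compound 3 the result > 40 ug/mL is such a limit. For compound 1 the result > 50 ug/mL is also a limit. For compound 2 the result > 40 ug/mL is a limit as well.

Compound 3 therefore stands at the lower of the two limits reached, the one that two of the three compounds share: the limit of > 40 ug/mL in this assay, at which 2 of the 3 values shown sit; the remaining compound sits at the limit of > 50 ug/mL in this assay, at which 1 of the 3 values shown sits. Because all three sit at limits, the steps between them cannot be read: a step that the two limits leave unreadable from compound 1 to compound 2, a step that the two limits leave unreadable from compound 1 to compound 3, a step that the two limits leave unreadable from compound 2 to compound 3.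

Compound 4 `COC(=O)c1cc(-c2cccc(NC(=O)c3ccc(/C=C/C(=O)c4ccc(CC(C)C)cc4)cc3)c2)on1` differs from compound 3 by 4-isobutylphenyl in place of 2,4-dichlorophenyl on a carbonyl carbon. Among the measured compounds shown here, the steps that bear on this change are those that swap the aryl group on the same carbonyl carbon, a step that the two limits leave unreadable from compound 1 to compound 3 and a step that the two limits leave unreadable from compound 2 to compound 3, and both are unreadable in size, so no direction can be taken from them. It is expected that compound 4 likewise reaches a limit in this assay, estimated at 45 ug/mL with a range from 20 ug/mL to 100 ug/mL. The expected step that the limit leaves unreadable from compound 3 to compound 4 is thus estimated to stay within the scatter.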

Compound 4, half-maximal cytotoxic concentration: > 10 ug/mL
Compound 4: a limit, no number; the forecaster's own chance of this, stated with the estimate: 80%; the middle value lies beyond the limit too.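

In this assay compound 4 gives > 10 ug/mL, which is a limit of the assay and not a number. The steps from compound 1, compound 2 and compound 3 to compound 4 cannot be read. Still open, going by these compounds, is where the half-maximal cytotoxic concentration of each of these four compounds lies, and whether the aryl group on the carbonyl carbon shifts it at all.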